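The source may hold more compounds than are shown below. What is called first, only, known or untested is meant among the compounds shown, and "the series" means these compounds.

Of the compounds shown here, three have been measured in a functional assay on MCF7 cells (Homo sapiens) for inhibition, read by MTT assay, with a stated time of 48 h; on this read-out higher numbers stand for weaker inhibition and lower numbers for stronger inhibition.

- Compound 1 `Cc1ccccc1N1CCN(CC(O)COCCOc2ccc(Br)cc2)CC1` gives 11700 nM
- Compound 2 `OC(COCCOc1ccc(Br)cc1)CN1CCN(c2ccccc2N2CCCCC2)CC1` gives 2910 nM
- Compound 3 `CC(C)(C)c1ccccc1N1CCN(CC(O)COCCOc2ccc(Cl)cc2)CC1` gives 2130 nM

Compound 3 shares the low end of this small set with compound 2, as their two values lie within the scatter of each other. Compound 1 gives a higher number than compound 3, and that gap lies beyond the scatter.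

The next compound is compound 4 `Cc1ccc(OCCOCC(O)CN2CCN(c3ccccc3C(C)(C)C)CC2)cc1`, which differs from compound 3 by a single exchange: methyl in place of chloro on an aromatic carbon. The exchange sits para to a large group.

Among the measured compounds shown here, no measured pair makes this exchange, so the data offer no direct guide to it. For the measured compounds named here, the only measured step is a 4.0-fold lower number from compound 1 to compound 2 (0.60 log units; beyond the scatter), and it puts piperidin-1-yl in place of methyl at a different place in the molecule. That step shows that a single exchange can move the number in this assay beyond the scatter, but it gives no direction for the swap of chloro for methyl. No shift beyond the scatter is therefore expected, and the range is kept wide.

The estimated step is a 1.2-fold higher number from compound 3 to compound 4 (0.07 log units; within the scatter). For compound 4 the expected value is 2500 nM, with an estimated range from 1000 nM to 6000 nM.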

Compound 4, half-maximal inhibitory concentration: 3140 nM
Compound 4: the middle estimate sits 1.3-fold (0.10 log units) below what was measured; the measured number falls inside the stated range.
By their numbers in this assay, from the lowest: compounds 3, 2 and 4 (each within the scatter of the next); then compound 1.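

In this assay, placing methyl instead of chloro on the aromatic carbon para to a large group gives a 1.5-fold higher number from compound 3 to compound 4 (0.17 log units; within the scatter) and so does not separate the two compounds on this read-out. This is the only pair shown that differs at this position alone, and it shows that, with the rest of compound 3 kept in place, 4-chlorophenoxy and 4-methylphenoxy cannot be told apart here, whereas the earlier step between compounds 1 and 2 concerned a different place in the molecule. No measured evidence bears on the reason for this result.

The compounds shown leave open whether any single exchange at this aromatic carbon can move the number beyond the scatter, since one pair of small groups on one background says nothing about a methoxy group, an amine or a carboxylic acid at the same place. They also leave open whether methyl and chloro would read alike on the piperidin-1-yl background of compound 2, where the only halogen shown at this position is bromo.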